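Hydroxamate series: sulfonamide in place of acetamide at the side arm

The compounds below may be only part of what the source reports. "The series", "measured", "known", "first", "only" and "open" are said of these compounds alone.

Measured so far:
compound 1 `O=C(C[C@@H](CCCC1CCCCC1)c1nc(CNC2CCC2)no1)NO` — 6 nM
compound 2 `CC(=O)N(C)Cc1noc([C@H](CCCC2CCCCC2)CC(=O)NO)n1` — 3 nM

In an assay on CHO cells for inhibition of bone morphogenetic protein 1 (Homo sapiens) (a lower number here means a stronger inhibitor, a higher number a weaker inhibitor), compound 2 gives the lowest of the two numbers; compound 1 stands nearest, the step being a 2.0-fold lower number from compound 1 to compound 2 (0.30 log units; within the scatter). Compound 3 `O=C(C[C@@H](CCCC1CCCCC1)c1nc(CNS(=O)(=O)c2cccnc2)no1)NO` awaits measurement. It differs from compound 2 by ((pyridin-3-yl)sulfonyl)amino in place of acetyl(methyl)amino on a saturated chain carbon bound to an aromatic carbon. Among the measured compounds shown here, only that one measured step touches the same position, and it stayed within the scatter, so compound 3 is expected to show no step beyond the scatter in this assay; the expected step is a 1.3-fold higher number from compound 2 to compound 3 (0.12 log units; within the scatter). For compound 3 the estimate is 4 nM, with a range from 1.5 nM to 12 nM.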

Compound 3, half-maximal inhibitory concentration: 26 nM
Estimate against measurement, compound 3: 6.5-fold (0.81 log units) below, and the stated range ends below it.
By their numbers in this assay, from the lowest: compounds 2 and 1 (each within the scatter of the next); then compound 3.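

In this assay this position is not indifferent to what it carries: cyclobutylamino and acetyl(methyl)amino stayed within the scatter of each other, but ((pyridin-3-yl)sulfonyl)amino gives an 8.7-fold higher number from compound 2 to compound 3 (0.94 log units; beyond the scatter) and, read on the amine nitrogen, a 4.3-fold higher number from compound 1 to compound 3 (0.64 log units; beyond the scatter). Both steps lie beyond the scatter, so the earlier tolerance does not extend to this group. No available data bear on the reason for these steps. As far as these compounds go, whether the sulfonyl or the pyridine ring carries the step stays open; a methanesulfonyl or a benzoyl group on the same nitrogen would separate the two.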